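This account rests on a few compounds, and the source may have more. Where it says the series, first, only, none or still open, it means among the compounds named here.

Working notes on the benzylpiperidine amide series.

Compound 1 `O=C(NCCC1CCN(Cc2ccccc2)CC1)c1coc2ccccc2c1=O` is the parent of this pair. Among the measured compounds shown here, in an assay on isolated protein for inhibition of Amine oxidase [flavin-containing] A (Homo sapiens), read by fluorescence and Amplex Red, with stated times of 15 min and 20 min, tested at 100 uM (on this read-out lower numbers stand for less inhibition and higher numbers for more inhibition at the one concentration tested (going by the name of the read-out)), compound 1 gives 68.6%, the highest of the two numbers measured so far. Compound 2 `Cc1ccc2occ(C(=O)NCCC3CCN(Cc4ccccc4)CC3)c(=O)c2c1` carries a methyl in place of hydrogen on an aromatic carbon of the shared core, and in this assay compound 2 gives 30.6%; the step of a number 38 percentage points lower from compound 1 to compound 2 (beyond the scatter) is large and beyond the scatter.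

Compound 3 `O=C(NCCC1CCN(Cc2ccccc2)CC1)c1coc2cc(Br)ccc2c1=O` is not yet measured. It differs from compound 1 by bromo in place of hydrogen on an aromatic carbon. For the measured compounds named here, only one measured step bears on it, that from compound 1 to compound 2, where a single small group entering an aromatic carbon of the same core cost a large amount of inhibition. The bromo enters at a different place on that ring, so the size of the effect is uncertain, but a decrease of moderate size is expected, a number 23.6 percentage points lower from compound 1 to compound 3 (beyond the scatter). Compound 3 is therefore estimated at 45%, with a range from 20% to 72% in this assay.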

Compound 3, a percentage reported as inhibition, at one concentration (the size of the read-out at that concentration, not a potency): 30.3%
Estimate against measurement, compound 3: 14.7 percentage points above; low and high end bracket the measured number.
By their numbers in this assay, from the lowest: compounds 3 and 2 (each within the scatter of the next); then compound 1.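

In this assay, bromo in place of hydrogen on this aromatic carbon, meta to a fused ring and para to a fused ring, gives a large loss: a number 38.3 percentage points lower from compound 1 to compound 3 (beyond the scatter). Alongside the methyl step, a number 38 percentage points lower from compound 1 to compound 2 (beyond the scatter), this shows that the loss is not tied to one carbon of that ring or to one group, since a second place and a second group each give a large step down from the unsubstituted compound 1. No available measurement bears on what lies behind either step.

Going by these compounds, it remains open whether any group at this carbon keeps the level of compound 1 at 68.6%, for example a fluoro or a methoxy. An amine or a carboxylic acid here could also be informative, as neither of the two groups shown carries a hydrogen-bond donor or a charge.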